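Thione and ketone analogues: fluoro for methoxy on the core

This account rests on a few compounds, and the source may have more. Where it says the series, first, only, none or still open, it means among the compounds named here.

Measured so far:
compound 1, `COc1ccc(-c2cc(=S)c3ccc(OC)cc3o2)cc1`: "not active" (no number reported)
compound 2, `Cc1ccc2c(=S)cc(-c3ccc(F)cc3)oc2c1`: "not active" (no number reported)
compound 3, `COc1ccc(-c2cc(=O)c3ccc(F)cc3o2)cc1`: 40%

In an in vitro assay on BTI-TN-5B1-4 cells for inhibition of Amine oxidase [flavin-containing] A (Homo sapiens), tested at 100 uM (a higher number here means more inhibition at the concentration tested (going by the name of the read-out), a lower number less inhibition), compound 1 gives "not active" (no number reported) and so stands without a single number. Compound 2 also gives "not active" (no number reported) in this assay. Compound 3 gives 40% in this assay, the only numbered entry of the three. Compound 4, `COc1ccc(-c2cc(=S)c3ccc(F)cc3o2)cc1`, differs from compound 1 by fluoro in place of methoxy on an aromatic carbon. Going by the values given here, no step between measured compounds is known. Compound 4 lies closer in structure to compound 1 and compound 2, both without a number, than to compound 3, so no step beyond the scatter is expected from compound 1, and a low read-out in this assay is expected. Compound 4 is estimated at 10%, within 0% to 35%.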

Compound 4, a percentage reported as inhibition, at one concentration (the size of the read-out at that concentration, not a potency): "not active" (no number reported)
Compound 4: no number reported; there is nothing to compare the estimate with.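

In this assay compound 1 gives "not active" (no number reported) and compound 4 gives "not active" (no number reported), so no step can be read between them. As far as these compounds go, whether fluoro in place of methoxy alters inhibition on this core stays open, and no supporting data bear on the result.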